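One Chain Extension, Tried on a Second Core

The source may hold more compounds than are shown below. What is called first, only, known or untested is meant among the compounds shown, and "the series" means these compounds.

Of the compounds shown here, three sharing a common core have been measured in a functional assay on NCI-H1299 cells (Homo sapiens) for inhibition, read by CCK-8 assay, with a stated time of 72 h, tested at 1 uM; a lower number here means a weaker effect, a higher number a stronger effect of the compound at the concentration tested. Compound 1, with the structure `CN(C)C(=O)c1cc2cnc(Nc3ccc(S(=O)(=O)NCCCCCN=C=S)cc3)nc2n1C1CCCC1`, gives 52.1%. Compound 2, with the structure `CN(C)C(=O)c1cc2cnc(Nc3ccc(S(=O)(=O)NCCCCCCN=C=S)cc3)nc2n1C1CCCC1`, gives 42.4%. The structural change from compound 1 to compound 2 is a group of 4 heavy atoms (2 carbon, 1 nitrogen, 1 sulfur; no ring) in place of a group of 3 heavy atoms (1 carbon, 1 nitrogen, 1 sulfur; no ring), on a saturated chain carbon, five bonds along the chain from a sulfonamide nitrogen. The step it made was a number 9.7 percentage points lower from compound 1 to compound 2 (within the scatter).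

Compound 3, with the structure `CN(C)C(=O)c1cc2cnc(Nc3ccc(C(=O)NCCCCCN=C=S)cc3F)nc2n1C1CCCC1`, gives 36.1% in this assay. Going by the values given here, the difference between the core of compound 3 and the core of compound 1 is not broken down here; the two values show only that compound 3 sits lower than compound 1 by a margin beyond the scatter, while its gap to compound 2 lies within the scatter.

Compound 4, with the structure `CN(C)C(=O)c1cc2cnc(Nc3ccc(C(=O)NCCCCCCN=C=S)cc3F)nc2n1C1CCCC1`, has not yet been measured. It differs from compound 3 by a group of 4 heavy atoms (2 carbon, 1 nitrogen, 1 sulfur; no ring) in place of a group of 3 heavy atoms (1 carbon, 1 nitrogen, 1 sulfur; no ring), on a saturated chain carbon, five bonds along the chain from an amide-type nitrogen. Among the compounds with values here, this is the same kind of change as the one made from compound 1 to compound 2, but not the same: in the earlier pair the chain carbon lies five bonds along the chain from a sulfonamide nitrogen, whereas in compound 3 and compound 4 it lies five bonds along the chain from an amide-type nitrogen.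

For compound 4 a step of a number 8.1 percentage points lower from compound 3 to compound 4 (within the scatter) is expected, an expectation resting on the step of a number 9.7 percentage points lower from compound 1 to compound 2 (within the scatter) seen in the first pair. Compound 4 is therefore estimated at 28% in this assay, with a likely span from 14% to 42%.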

Compound 4, a percentage reported as inhibition, at one concentration (the size of the read-out at that concentration, not a potency): 29.1%
Beside the measured number, compound 4's estimate is 1.1 percentage points below it; measured number inside the range.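

On the core of compound 3, putting the group of 4 heavy atoms in place of the group of 3 heavy atoms, on a saturated chain carbon, gives in this assay a result of a number 7 percentage points lower from compound 3 to compound 4 (within the scatter). Set beside the same change on the core of compound 1, the two steps do not differ, so in this series the change reads alike on both cores: the same change on two cores in this assay, a number 9.7 percentage points lower (within the scatter) from compound 1 to compound 2 and a number 7 percentage points lower (within the scatter) from compound 3 to compound 4, 2.7 percentage points apart, within the scatter of two such steps. This does not show that the change has a real effect on either core, as each step lies within the scatter, and two cores read at a single concentration in one cell line say nothing about other cores, other cells or other concentrations.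

The compounds shown leave open how a shorter or a much longer chain would read in this assay, and whether an amine or an acrylamide in place of the sulfur-bearing group would keep the reading at all. They also leave the sulfonamide and amide links without a direct comparison, as compound 1 and compound 3 differ in more than one place.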